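The source may report more compounds than this note shows. Statements on the series, on what has been measured and on what is new or still open speak of the compounds shown alone.

Compound 1 `CCCCCCCCCCCCOc1ccc2c(=O)c(-c3ccc(O)cc3)coc2c1`: > 9000 nM
Compound 2 `O=c1c(-c2ccc(O)cc2)coc2cc(OCCCCCCCCCCCCO)ccc12`: 1700 nM

In an assay (Cricetulus griseus) for inhibition of aldehyde dehydrogenase, mitochondrial (Homo sapiens) (a higher number here means a weaker inhibitor, a lower number a stronger inhibitor), compound 2 gives 1700 nM. Compound 1 gives > 9000 nM, which is a limit of the assay rather than a number. For the measured compounds named here, compound 2 therefore holds the only real number among the two measured compounds, the other value being a limit. Compound 3 `O=C(O)CCCCCCCCCCCOc1ccc2c(=O)c(-c3ccc(O)cc3)coc2c1` is not yet measured; it differs from compound 2 by carboxy in place of hydroxymethyl on a saturated chain carbon, ten or more bonds along the chain from an oxygen on an aromatic ring. Going by the values given here, only one measured step bears on this end of the chain: an at least 5.2-fold lower number from compound 1 to compound 2 (0.72 log units; beyond the scatter), a change at the same far end that put hydroxy in place of hydrogen, with one side of that step resting on the limit (the limit of > 9000 nM in this assay, at which 1 of the 2 values shown sits). Among the compounds with values here, no measured step covers an exchange of hydroxymethyl for carboxy, so the expectation stays close to compound 2. The expected step of a 1.2-fold higher number from compound 2 to compound 3 (0.07 log units; within the scatter) is none beyond the scatter. Compound 3 is estimated at 2000 nM, between 600 nM and 7000 nM.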

Compound 3, half-maximal inhibitory concentration: 130 nM
Compound 3: middle estimate off by 15-fold (1.19 log units), on the high side; measured number below the stated range.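

In this assay, for the compounds shown here, the earlier compounds showed only that adding hydroxy at the far end of the chain helps, and this result shows that the identity of the end group also matters: carboxy in place of hydroxymethyl gives a 13-fold lower number from compound 2 to compound 3 (1.12 log units; beyond the scatter). Both groups count the same hydrogen-bond donors and acceptors, so that count alone does not separate them. Compound 1 stands at a limit of the assay, so the step of an at least 69-fold lower number from compound 1 to compound 3 (1.84 log units; beyond the scatter) gives only a bound and not an exact size: the limit of > 9000 nM in this assay, at which 1 of the 3 values shown sits.

As far as these compounds go, what remains open is whether the effect needs carboxy itself, or whether a methyl ester or an amide at the same chain end would do as well. Also open, from the compounds shown here alone, is whether a shorter or a longer chain ending in carboxy would keep this strength.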